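Extending the Alkyl Chain of Compound 1

A few compounds are considered here, and "the series" means these few. Any claim that something is new, unique, unknown or untested is made for them only; others in the source may bear on it.

Compound 1 `CCc1ccc(NS(=O)(=O)c2ccc(N3CCNC3=O)cc2)cc1` gives 480 nM in a functional assay on M21 cells (Homo sapiens) for antiproliferative activity, read by sulforhodamine B assay, with a stated time of 48 h (on this read-out lower numbers stand for stronger inhibition and higher numbers for weaker inhibition), the highest of the three numbers recorded. Compound 2 `O=C1NCCN1c1ccc(S(=O)(=O)Nc2ccc(F)c(F)c2)cc1` gives 220 nM and compound 3 `O=C1NCCN1c1ccc(S(=O)(=O)Nc2cccc(Cl)c2)cc1` gives 25 nM; the steps of a 2.2-fold lower number from compound 1 to compound 2 (0.34 log units; beyond the scatter) and a 19-fold lower number from compound 1 to compound 3 (1.28 log units; beyond the scatter) both exchange the whole ring on the sulfonamide nitrogen, as does an 8.8-fold lower number from compound 2 to compound 3 (0.94 log units; beyond the scatter). Compound 4 `CC(C)Cc1ccc(NS(=O)(=O)c2ccc(N3CCNC3=O)cc2)cc1` differs from compound 1 only by isopropyl in place of methyl on a saturated chain carbon bound to an aromatic carbon. Among the measured compounds shown here, none of the measured steps touches that chain, and the shared core stays unchanged, so they offer no direct guide. Compound 4 is therefore expected to stay within the scatter of compound 1, a step of a 1.0-fold higher number from compound 1 to compound 4 (0.02 log units; within the scatter) in this assay. The estimate for compound 4 is 500 nM, with an expected range of 150 nM to 1600 nM.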

Compound 4, half-maximal inhibitory concentration: > 1000 nM
Compound 4: no number, only a limit; the forecaster's own chance of this, stated with the estimate: 5%; at least 2.0-fold (0.30 log units) between middle value and limit.
By their numbers in this assay, from the lowest: compound 3; then compound 2; then compound 1. At a limit, above all of these: compound 4.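

Compound 4 gives no number, only a limit: the limit of > 1000 nM in this assay, at which 1 of the 4 values shown sits. Even so, replacing ethyl with isobutyl on the ring of compound 1 is not a neutral change, giving an at least 2.0-fold higher number from compound 1 to compound 4 (0.31 log units; beyond the scatter), so this chain, which no other step shown touches, does bear on antiproliferative activity. The limit leaves the full size of that loss unknown.

As far as these compounds go, whether a straight propyl chain would follow isobutyl remains open. So does whether an amine or a carboxylic acid at the end of the chain would change the outcome.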